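Ring Contraction on the Core of Compound 2

The source may report more compounds than this note shows. Statements on the series, on what has been measured and on what is new or still open speak of the compounds shown alone.

Of the compounds shown here, two have been measured in an ADME assay on microsomes from liver (Rattus norvegicus, strain Wistar) for metabolic stability, tested at 2.5 uM; a lower number here means slower removal, a higher number faster removal of the compound. Compound 1 `c1ccc(-c2ccc(Cn3nnc4ccccc43)cc2)cc1` gives 12.6 mL/min/g in this assay. Among the measured compounds shown here, compound 2 `Brc1cccc2c1nnn2CC1CCCC1` gives 14.6 mL/min/g, a number that sits within the usual scatter of the one for compound 1, so the two cannot be told apart. Compound 3 `Brc1cccc2c1nnn2CC1CCC1` has not been measured; it differs from compound 2 in one place: cyclobutyl in place of cyclopentyl on a saturated chain carbon bound to an aromatic nitrogen. For the measured compounds named here, with no comparable step among the measured compounds to draw on, the step of a 1.2-fold lower number from compound 2 to compound 3 (0.09 log units; within the scatter) is expected to stay within the scatter. Compound 3 is therefore estimated at 12 mL/min/g in this assay, with a range from 6 mL/min/g to 25 mL/min/g.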

Compound 3, intrinsic clearance in a liver preparation (reported as CLH), per the amount of preparation that the assay uses: 12 mL/min/g
For compound 3 middle estimate and measured number coincide at the digits printed, within the range that was stated.
By their numbers in this assay, from the lowest: compounds 3, 1 and 2 (each within the scatter of the next).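

In this assay, among the compounds shown here, the step of a 1.2-fold lower number from compound 2 to compound 3 (0.09 log units; within the scatter) is the first one available at this position, and it shows that cyclobutyl in place of cyclopentyl on a saturated chain carbon bound to an aromatic nitrogen does not separate the two compounds. So far, this position tolerates the swap between these two carbon rings without a readable difference. Nothing measured here bears on the reason for this.

On these data alone, whether an amine, a carboxylic acid or a longer chain at this position would also stay within the scatter remains open. So does whether the same ring swap would read alike on the core of compound 1.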